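Swapping an aryl amide for an aminoalkyl amide

A few compounds are considered here, and "the series" means these few. Any claim that something is new, unique, unknown or untested is made for them only; others in the source may bear on it.

Of the compounds shown here, three have been measured in a functional assay on PC-3 cells (Homo sapiens) for cytotoxicity, read by MTT assay, with a stated time of 48 h; a lower number here means a stronger inhibitor, a higher number a weaker inhibitor. Compound 1 `CC1=NN(S(=O)(=O)c2ccc(C)cc2)C(c2cc(Br)ccc2O)C1` gives 33200 nM, compound 2 `CC1=NN(C(=O)CN2CCCC2)C(c2ccccc2O)C1` gives 6670 nM, and compound 3 `O=C(c1ccccc1Cl)N1N=C(c2cc3ccccc3oc2=O)CC1c1ccccc1` gives 6370 nM. Compound 3 holds the lowest of the three numbers, yet its gap to compound 2 lies within the scatter, while its gap to compound 1 lies beyond it. Compound 4 `CCN(CC)C1CCN(CC(=O)N2N=C(c3cc4ccccc4oc3=O)CC2c2ccccc2)CC1` has not been measured; it differs from compound 3 in one place: (4-(diethylamino)piperidin-1-yl)methyl in place of 2-chlorophenyl on a carbonyl carbon. Within the data shown here, no measured pair shows this change, but compound 2 carries a related group on its carbonyl carbon and gives 6670 nM, and compound 3 gives 6370 nM. The step of a 1.1-fold higher number from compound 3 to compound 4 (0.04 log units; within the scatter) is therefore expected to stay within the scatter. Compound 4 is estimated at 7000 nM, with a range from 2500 nM to 20000 nM.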

Compound 4, half-maximal inhibitory concentration: 26100 nM
Compound 4: middle estimate off by 3.7-fold (0.57 log units), on the low side, and the stated range ends below it.
By their numbers in this assay, from the lowest: compounds 3 and 2 (each within the scatter of the next); then compounds 4 and 1 (each within the scatter of the next).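

On this carbonyl carbon, whose other neighbour is the amide-type nitrogen in a ring, the swap of 2-chlorophenyl for (4-(diethylamino)piperidin-1-yl)methyl is not neutral: in this assay it gives a 4.1-fold higher number from compound 3 to compound 4 (0.61 log units; beyond the scatter). Among these compounds, this is the first step read at this position, and it shows that the number responds to the group placed there. No measurement shown bears on why the number rises.

Still open, from the compounds shown here alone, is which part of the entering group matters: a plain piperidin-1-ylmethyl group or a morpholin-4-ylmethyl group on the same carbonyl carbon would begin to separate the terminal diethylamino group from the rest.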